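Thiophen-2-yl for phenyl on the imine carbon

The source may hold more compounds than are shown below. What is called first, only, known or untested is meant among the compounds shown, and "the series" means these compounds.

The series is followed in a functional assay on HeLa cells (Homo sapiens) for antiproliferative activity, read by MTT assay; on this read-out lower numbers stand for stronger inhibition and higher numbers for weaker inhibition. Compound 1 `NS(=O)(=O)c1ccc(Nc2ncc(/N=C/c3cccs3)c(NC3CCCC3)n2)cc1` gives 10900 nM in this assay. Compound 2 `CC(C)Nc1nc(Nc2ccc(N3CCN(C)CC3)cc2)ncc1/N=C/c1cccs1` differs from compound 1 in several places. In this assay compound 2 gives 77100 nM. Compound 3 `CC(C)Nc1nc(Nc2ccc(S(N)(=O)=O)cc2)ncc1/N=C/c1ccccc1` stands at the weak end of the numbers shown: in this assay compound 3 gives only a limit, > 100000 nM, and no number, as noted in the limit of > 100000 nM in this assay, at which 1 of the 3 values shown sits. Compound 3 therefore sits apart from compound 1 and compound 2, whose values are numbers, though how far apart cannot be told from a limit.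

The next compound, compound 4 `CC(C)Nc1nc(Nc2ccc(S(N)(=O)=O)cc2)ncc1/N=C/c1cccs1`, is compound 3 with thiophen-2-yl in place of phenyl on a carbon with a double bond to nitrogen. Among the measured compounds shown here, no pair of measured compounds shows this exact change on its own; compound 1 and compound 2 both carry the thiophen-2-yl group and both give numbers in this assay, whereas compound 3 with phenyl gives only a limit. On that basis the step from compound 3 to compound 4 is expected to go toward stronger inhibition, an at least 3.3-fold lower number from compound 3 to compound 4 (0.52 log units; beyond the scatter), beyond the scatter. For compound 4 in this assay the estimate is 30000 nM, with a range from 8000 nM to 100000 nM.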

Compound 4, half-maximal inhibitory concentration: > 100000 nM
Compound 4: no number, only a limit; the forecaster's own chance of this, stated with the estimate: 30%; middle value at least 3.3-fold (0.52 log units) away from the limit.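

In this assay, thiophen-2-yl in place of phenyl on a carbon with a double bond to nitrogen brings no number into range while isopropyl and sulfamoyl stay in place; the step between compound 3 and compound 4 cannot be read, as both give limits and not numbers. The thiophen-2-yl group alone is therefore not enough for a measurable value: isopropyl in place of cyclopentyl on a nitrogen on an aromatic ring gives an at least 9.1-fold higher number from compound 1 to compound 4 (0.96 log units; beyond the scatter), while sulfamoyl in place of 4-methylpiperazin-1-yl on an aromatic carbon gives an at least 1.2-fold higher number from compound 2 to compound 4 (0.11 log units; that floor lies within the scatter), a floor that does not separate compound 2 from compound 4 beyond the scatter. The limit now holds both the phenyl compound and the thiophen-2-yl compound: the limit of > 100000 nM in this assay, at which 2 of the 4 values shown sit.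

As far as these compounds go, whether phenyl and thiophen-2-yl differ at all on this carbon stays open, and a phenyl partner of compound 1, with cyclopentyl on the nitrogen, could give a readable comparison. Also open, from the compounds shown here alone, is how a furan-2-yl group on the same carbon, or a cyclohexyl group in place of cyclopentyl on the nitrogen, would read out.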